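Methyl in Place of Isopropyl: Expected Stability of Compound 4

A few compounds are considered here, and "the series" means these few. Any claim that something is new, unique, unknown or untested is made for them only; others in the source may bear on it.

Three esters sharing one core have been measured in an ADME assay on microsomes from liver (Homo sapiens) for metabolic stability, with a stated time of 30 min; on this read-out lower numbers stand for a less stable compound and higher numbers for a more stable compound. Compound 1 `CCCCc1nc(C(C)C)c(CC(=O)OCC(C)C)c(=O)n1Cc1ccc(-c2ccccc2-c2noc(=O)[nH]2)cc1` gives 8.8%. Compound 2 `CCCCc1nc(C(C)C)c(CC(=O)OC2CC2)c(=O)n1Cc1ccc(-c2ccccc2-c2noc(=O)[nH]2)cc1` gives 10.3%, and compound 3 `CCCCc1nc(C(C)C)c(CC(=O)OC(CC)CC)c(=O)n1Cc1ccc(-c2ccccc2-c2noc(=O)[nH]2)cc1` gives 7.7%. Compound 1 thus sits with the other two, its nearest neighbour compound 3 and its furthest neighbour compound 2 both lying within the scatter. The steps of a number 1.5 percentage points higher from compound 1 to compound 2 (within the scatter), a number 1.1 percentage points lower from compound 1 to compound 3 (within the scatter) and a number 2.6 percentage points lower from compound 2 to compound 3 (within the scatter) each change only the group on the oxygen next to the carbonyl, and none of them reaches beyond the scatter. Compound 4 `CCCCc1nc(C)c(CC(=O)OCC(C)C)c(=O)n1Cc1ccc(-c2ccccc2-c2noc(=O)[nH]2)cc1` differs from compound 1 at another place: methyl in place of isopropyl on an aromatic carbon. Among the measured compounds shown here, no measured step touches that aromatic carbon, so the expectation can rest only on the narrow spread of the three known values. The step from compound 1 to compound 4 in this assay is therefore expected to be a number 0.2 percentage points higher from compound 1 to compound 4 (within the scatter), not beyond the scatter. Compound 4 is estimated to give 9%, with a range from 4% to 17%.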

Compound 4, percent of the compound remaining: 2.4%
Estimate against measurement, compound 4: 6.6 percentage points above, and the stated range ends above it.
By their numbers in this assay, from the lowest: compounds 4, 3, 1 and 2 (each within the scatter of the next).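

Among the compounds shown here, the first change at this aromatic carbon, methyl in place of isopropyl on the six-membered aromatic ring, gives a number 6.4 percentage points lower from compound 1 to compound 4 (within the scatter) in this assay. This is the largest step seen so far in the series, yet it remains within the scatter, so the change cannot be told apart from repeat variation, just like the changes on the ester oxygen. Nothing available bears on what lies behind this step.

Going by these compounds, what an amine, a carboxylic acid or a longer chain on this aromatic carbon would do in this assay remains open. Also open, on these data alone, is whether methyl in place of isopropyl gives a comparable step when cyclopropyl or pentan-3-yl sits on the ester oxygen instead of isobutyl.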